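The source may report more compounds than this note shows. Statements on the series, on what has been measured and on what is new or still open speak of the compounds shown alone.

Three compounds that share one core and differ only in a ring group on an aromatic carbon have been measured in a functional assay on L1210 cells (Mus musculus) for antiproliferative activity; on this read-out lower numbers stand for stronger inhibition and higher numbers for weaker inhibition. Compound 3 `COc1cc(C(=O)c2sc(-c3ccsc3)cc2N)cc(OC)c1OC`, with thiophen-3-yl, gives the lowest number, 12 nM. Compound 1 `COc1cc(C(=O)c2sc(-c3ccc([N+](=O)[O-])cc3)cc2N)cc(OC)c1OC`, with 4-nitrophenyl, gives 100 nM. Compound 2 `COc1cc(C(=O)c2sc(-c3ccncc3)cc2N)cc(OC)c1OC`, with pyridin-4-yl, gives 1810 nM.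

Compound 4 `COc1cccc(-c2cc(N)c(C(=O)c3cc(OC)c(OC)c(OC)c3)s2)c1` has 3-methoxyphenyl in place of thiophen-3-yl on an aromatic carbon. This position clearly matters, as an 18-fold higher number from compound 1 to compound 2 (1.26 log units; beyond the scatter) shows. Both measured steps that bring in thiophen-3-yl lower the number: an 8.3-fold lower number from compound 1 to compound 3 (0.92 log units; beyond the scatter), and a 150-fold lower number from compound 2 to compound 3 (2.18 log units; beyond the scatter). The first is the closer guide, a modest step in which 4-nitrophenyl leaves, and 3-methoxyphenyl is likewise a six-membered aromatic ring of carbon only. Among the compounds with values here, no measured compound carries a methoxy group on this ring, so the uncertainty is wide.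

A modest rise in this assay is therefore expected, read as a 5.0-fold higher number from compound 3 to compound 4 (0.70 log units; beyond the scatter). Compound 4 is estimated at 60 nM, with an expected range of 15 nM to 300 nM.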

Compound 4, half-maximal inhibitory concentration: 22 nM
The estimate for compound 4 lay 2.7-fold (0.44 log units) above the measured number; the measured number falls inside the stated range.
By their numbers in this assay, from the lowest: compounds 3 and 4 (each within the scatter of the next); then compound 1; then compound 2.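

In this assay, 3-methoxyphenyl in place of thiophen-3-yl gives a 1.8-fold higher number from compound 3 to compound 4 (0.26 log units; within the scatter) and stays within the scatter, so this position accepts either ring without a change that can be told apart. Before this, the only six-membered ring of carbon only was 4-nitrophenyl, and 3-methoxyphenyl in its place gives a 4.5-fold lower number from compound 1 to compound 4 (0.66 log units; beyond the scatter) and shows that such a ring need not cost activity. Ring size alone does not set the number either, as six-membered rings now stand at both ends of the series, with an 82-fold lower number from compound 2 to compound 4 (1.92 log units; beyond the scatter) in going from pyridin-4-yl to 3-methoxyphenyl.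

The compounds shown leave open how a plain phenyl ring would fare, or one carrying an amine or a carboxylic acid in place of the methoxy group. No evidence is available on what lies behind these differences.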